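This account rests on a few compounds, and the source may have more. Where it says the series, first, only, none or still open, it means among the compounds named here.

Measured so far:
compound 1 `COc1ccc(-c2nc3cc(C(C)O)ccc3[nH]2)c(OC)c1`: >= 100000 nM
compound 2 `COc1ccc(-c2nc3cc(/C(C)=N/NC(N)=O)ccc3[nH]2)cc1`: "not determined" (no result reported)

In an ADME assay on MT4 cells (Homo sapiens) for cytotoxicity, read by MTT assay, with a stated time of 96 h (a higher number here means that more compound is tolerated, a lower number that less compound is tolerated), compound 2 has no number, as its entry reads "not determined" (no result reported). Its standing on the scale is therefore unknown. In this assay compound 1 gives >= 100000 nM, and this is a limit of the assay, not a number. The only mark on the scale so far is the limit of >= 100000 nM in this assay, at which 1 of the 2 values shown sits.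

Next comes compound 3 `COc1ccc(-c2nc3cc(/C(C)=N/NC(N)=O)ccc3[nH]2)c(OC)c1`, still to be measured. The structural change is methoxy in place of hydrogen on an aromatic carbon. Among the measured compounds shown here, no measured pair shows what such a change does, so the expected step in this assay is none beyond the scatter, in either direction. Compound 3 is estimated at 60000 nM, with an expected range of 15000 nM to 100000 nM.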

Compound 3, half-maximal cytotoxic concentration: 21000 nM
Estimate against measurement, compound 3: 2.9-fold (0.46 log units) above; the measured number falls inside the stated range.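

Among the compounds shown here, compound 3 gives the first true number on this scale, so a ceiling on tolerated compound now shows up in this assay for a compound carrying methoxy on an aromatic carbon, ortho to a large group. Putting a group of 7 heavy atoms in place of a group of 3 heavy atoms goes with an at least 4.7-fold lower number from compound 1 to compound 3 (0.67 log units; beyond the scatter), a change that lies beyond the scatter. This size is only a minimum because one end of the step is a limit of the assay and not a number: the limit of >= 100000 nM in this assay, at which 1 of the 3 values shown sits.

On these data alone, the step from hydrogen to methoxy cannot be read, since compound 2 has no number, so the methoxy group's own share stays unknown. Also open, as far as these compounds go, is how an ethoxy group or a chlorine atom at that carbon, or an amine in place of the group of 7 heavy atoms, would compare.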